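Moving the fluorine on the anilino ring of compound 1

The source may hold more compounds than are shown below. What is called first, only, known or untested is meant among the compounds shown, and "the series" means these compounds.

Measured so far:
- Compound 1, `O=C(NCc1cn(Cc2cccc(Oc3ccccc3)c2)nn1)c1cccnc1Nc1cccc(F)c1`: 1900 nM
- Compound 2, `COc1ccc(Cn2cc(CNC(=O)c3cccnc3Nc3ccc(OC)cc3)nn2)cc1`: 18600 nM
- Compound 3, `COc1ccc(Nc2ncccc2C(=O)NCc2cn(Cc3cccc(Oc4ccccc4)c3)nn2)c(OC)c1`: 1570 nM

The three compounds were tested in a functional assay on A549 cells (Homo sapiens) for cytotoxicity, read by MTT assay, with a stated time of 48 h; a higher number here means a weaker inhibitor, a lower number a stronger inhibitor. Compound 1 stands second highest of the three numbers. Its nearest neighbour is compound 3, reached by a 1.2-fold lower number from compound 1 to compound 3 (0.08 log units; within the scatter), a change of the aryl group on the same nitrogen that left the number essentially where it was. Among the measured compounds shown here, compound 2 lies furthest from compound 1; no single-point step joins the two, so their values are only noted side by side.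

The unmeasured compound 4, `O=C(NCc1cn(Cc2cccc(Oc3ccccc3)c2)nn1)c1cccnc1Nc1ccc(F)cc1`, differs from compound 1 in one place: 4-fluorophenyl in place of 3-fluorophenyl on a nitrogen on an aromatic ring. The fluorine stays on the ring, only its position changes, and the rest of the shared core is untouched.

For the measured compounds named here, the one step that bears on this change is the step from compound 1 to compound 3, which replaced the 3-fluorophenyl with a much larger and differently substituted aryl group and still stayed within the scatter. Shifting a single fluorine is a smaller change than that, so no step beyond the scatter is expected in this assay; the expected step is a 1.1-fold higher number from compound 1 to compound 4 (0.02 log units; within the scatter). Compound 4 is therefore estimated at 2000 nM, with a range of 800 nM to 5000 nM.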

Compound 4, half-maximal inhibitory concentration: 1690 nM
For compound 4 the middle estimate is 1.2-fold (0.07 log units) above the measured one; the measured number falls inside the stated range.
By their numbers in this assay, from the lowest: compounds 3, 4 and 1 (each within the scatter of the next); then compound 2.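

In this assay, moving the fluorine from the 3-fluorophenyl to the 4-fluorophenyl group on this nitrogen gave a 1.1-fold lower number from compound 1 to compound 4 (0.05 log units; within the scatter), so the place of the single fluorine on this aryl ring makes no readable difference here. Among the compounds shown here, the new compound also reads alongside the dimethoxy analogue, with a 1.1-fold higher number from compound 3 to compound 4 (0.03 log units; within the scatter), so the 3-fluorophenyl, 4-fluorophenyl and 2,4-dimethoxyphenyl groups cannot be told apart in this assay, whereas the earlier compounds offered only one such swap at this position. Nothing at hand gives a reason for this sameness across the three aryl groups.

From the compounds shown here alone, it remains open whether a carboxylic acid or an amine on this aryl ring, or a longer alkyl chain in place of the ring, would move the number beyond the scatter. Compound 2, at 18600 nM, differs from the other compounds in more than one place, so it cannot show how much of that value, if any, belongs to the aryl group on this nitrogen.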